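The compounds below may be only part of what the source reports. "The series", "measured", "known", "first", "only" and "open" are said of these compounds alone.

Working notes on the series. Compound 1 `Cc1ccsc1C(=CCCN(C)C(CCO)C(=O)NCc1ccccc1)c1sccc1C` gives in a physicochemical assay for lipophilicity, read by HPLC (on this read-out lower numbers stand for lower lipophilicity and higher numbers for higher lipophilicity), a value of 5.71; compound 2 `Cc1ccsc1C(=CCCN(C)C(CCN)C(=O)NCc1ccccc1)c1sccc1C` gives 5.5; compound 3 `Cc1ccc(CNC(=O)C(CCN)N(C)CCC=C(c2sccc2C)c2sccc2C)cc1` gives 6.61. Compound 2 and compound 1 differ by hydroxy in place of amino on a saturated chain carbon, three bonds along the chain from an amine nitrogen and a carbonyl carbon, and that change made a step of a number 0.21 log units higher from compound 2 to compound 1 (within the scatter). The cores of compound 2 and compound 3 differ by methyl in place of hydrogen on an aromatic carbon, with a step of a number 1.11 log units higher from compound 2 to compound 3 (beyond the scatter); compound 3 stands highest of the three measured in this assay. Compound 4 `Cc1ccc(CNC(=O)C(CCO)N(C)CCC=C(c2sccc2C)c2sccc2C)cc1` is not yet measured. It differs from compound 3 by hydroxy in place of amino on a saturated chain carbon, three bonds along the chain from an amine nitrogen and a carbonyl carbon, the same change as from compound 2 to compound 1, at the same place. Resting on the earlier step, a number 0.21 log units higher from compound 2 to compound 1 (within the scatter), the expected step for compound 4 is a number 0.19 log units higher from compound 3 to compound 4 (within the scatter). Compound 4 is therefore estimated in this assay at 6.8, expected to lie between 6.4 and 7.2.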

Compound 4, partition coefficient: 6.2
Estimate against measurement, compound 4: 0.60 log units above; the measured number lies below the stated range.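

In this assay, hydroxy in place of amino does not carry over unchanged from one core to the other: on the core of compound 2 it gives a number 0.21 log units higher from compound 2 to compound 1 (within the scatter), while on the core of compound 3 it gives a number 0.41 log units lower from compound 3 to compound 4 (beyond the scatter). Methyl in place of hydrogen on an aromatic carbon points the same way with either chain, with a number 1.11 log units higher from compound 2 to compound 3 (beyond the scatter) and a number 0.49 log units higher from compound 1 to compound 4 (beyond the scatter). Two pairs show that the step depends on the core here, but not how it would behave on any other core, and nothing measured bears on the reason.

The compounds shown leave open how the change reads on a core with chloro in place of that methyl. They also leave open how a carboxylic acid or a longer chain ending in hydroxy would compare with 2-aminoethyl and 2-hydroxyethyl.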